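Working notes: methyl for hydrogen, compound 2 to compound 4

A few compounds are considered here, and "the series" means these few. Any claim that something is new, unique, unknown or untested is made for them only; others in the source may bear on it.

Measured so far:
compound 1 `CCS[C@@H]1[C@H](SCC)[C@@H](Cn2cc(-c3ccc(F)cc3)nn2)O[C@H]1n1ccc(=O)[nH]c1=O`: 22900 nM
compound 2 `CCS[C@@H]1[C@H](SCC)[C@@H](Cn2cc(-c3ccccc3C(F)(F)F)nn2)O[C@H]1n1ccc(=O)[nH]c1=O`: 19400 nM
compound 3 `CCS[C@@H]1[C@H](SCC)[C@@H](Cn2cc(-c3cccc(C)c3)nn2)O[C@H]1n1ccc(=O)[nH]c1=O`: 12200 nM

In a functional assay on A549 cells (Homo sapiens) for cytotoxicity, read by MTT assay, with a stated time of 72 h (on this read-out higher numbers stand for an effect only at larger amounts of compound and lower numbers for an effect already at smaller amounts), compound 2 gives 19400 nM, the second highest of the three numbers. Its neighbours sit close: a 1.2-fold lower number from compound 1 to compound 2 (0.07 log units; within the scatter) and a 1.6-fold lower number from compound 2 to compound 3 (0.20 log units; within the scatter), and the remaining step, a 1.9-fold lower number from compound 1 to compound 3 (0.27 log units; within the scatter), is also within scatter. All three steps exchange one aryl group for another; none touches the other ring of the shared core.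

Compound 4 `CCS[C@@H]1[C@H](SCC)[C@@H](Cn2cc(-c3ccccc3C(F)(F)F)nn2)O[C@H]1n1cc(C)c(=O)[nH]c1=O` differs from compound 2 by methyl in place of hydrogen on an aromatic carbon. Going by the values given here, no measured step bears on that position, so no direct guide exists; the only indication is that every substitution so far left this assay within scatter. The step expected is therefore a 1.0-fold lower number from compound 2 to compound 4 (0.01 log units; within the scatter), none beyond scatter. Compound 4 is estimated at 19000 nM, range 8000 nM to 45000 nM.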

Compound 4, half-maximal effective concentration: 7230 nM
Compound 4: middle estimate off by 2.6-fold (0.42 log units), on the high side, and the stated range ends above it.
By their numbers in this assay, from the lowest: compounds 4, 3, 2 and 1 (each within the scatter of the next, the first and the last beyond it).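

Unlike the three aryl exchanges, methyl in place of hydrogen on the six-membered aromatic ring with 2 nitrogen gives a step beyond the scatter in this assay, with a 2.7-fold lower number from compound 2 to compound 4 (0.43 log units; beyond the scatter) as the result. This position therefore affects the read-out, at least with the 2-(trifluoromethyl)phenyl group present. No measurement at hand explains the step.

As far as these compounds go, it remains open whether the same methyl step holds with the aryl groups of compound 1 and compound 3. Also open, from the compounds shown here alone, is how an ethyl group, a chlorine or an amine at this position would compare.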